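From chloro to dimethylamino on a long chain

The source may hold more compounds than are shown below. What is called first, only, known or untested is meant among the compounds shown, and "the series" means these compounds.

Measured in a functional assay on HCT-116 cells (Homo sapiens) for antiproliferative activity, read by MTT assay, with a stated time of 48 h; on this read-out lower numbers stand for stronger inhibition and higher numbers for weaker inhibition
Compound 1 `CCCCCC(CCO)n1cnc2c(N(C)C)ncnc21` gives > 50000 nM as a limit of the assay, not a number
Compound 2 `CCCCCCCCC(CCO)n1cnc2c(Cl)ncnc21` gives 1650 nM as its value
Compound 3 `CCCCCCCCCC(CCO)n1cnc2c(Cl)ncnc21` gives 890 nM as its value

Compound 3 sits level with compound 2 within the scatter, and the only other result is the limit of compound 1. Compound 4 `CCCCCCCCCC(CCO)n1cnc2c(N(C)C)ncnc21` puts dimethylamino in place of chloro on an aromatic carbon and keeps the chain of compound 3 unchanged. For the measured compounds named here, the one measured step is a 1.9-fold lower number from compound 2 to compound 3 (0.27 log units; within the scatter) and it alters only the chain, so it says little about this swap. Going by the values given here, no measured pair makes the swap directly. The nearest clue is compound 1, which carries dimethylamino on a different chain and reaches only > 50000 nM as a limit. Weaker inhibition is therefore expected, though the longer chain of compound 4 may keep a measurable number in reach. The expected step is a 17-fold higher number from compound 3 to compound 4 (1.23 log units; beyond the scatter) and it points towards a higher number. In this assay the estimate for compound 4 is 15000 nM with an expected range from 3000 nM to 50000 nM as its bounds.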

Compound 4, half-maximal inhibitory concentration: 9810 nM
Compound 4: middle estimate off by 1.5-fold (0.18 log units), on the high side, and the stated range covers the measured number.
By their numbers in this assay, from the lowest: compounds 3 and 2 (each within the scatter of the next); then compound 4. At a limit, above all of these: compound 1.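

In this assay, for the compounds shown here, the one direct reading of this swap on an unchanged chain is an 11-fold higher number from compound 3 to compound 4 (1.04 log units; beyond the scatter), so dimethylamino in place of chloro on an aromatic carbon clearly weakens inhibition here. The chain still matters with dimethylamino in place, since butyl in place of hydrogen on a saturated chain carbon gives an at least 5.0-fold lower number from compound 1 to compound 4 (0.70 log units; beyond the scatter), a change the chloro pair of compounds 2 and 3 could not show, its own step staying within the scatter. The size of that step stays open-ended, as compound 1 has a limit and not a number: the limit of > 50000 nM in this assay, at which 1 of the 4 values shown sits.

As far as these compounds go, whether a longer chain would lower the number for the dimethylamino compounds further remains open. So does how smaller groups on the same aromatic carbon, such as a methylamino group or an unsubstituted amine, would compare with chloro and dimethylamino.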